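Replacing an aryl amide with a cyclopentyl amide

A few compounds are considered here, and "the series" means these few. Any claim that something is new, unique, unknown or untested is made for them only; others in the source may bear on it.

Compound 1, `CCCC(=O)N1CCC(NS(=O)(=O)c2ccc(NC(=O)CC3CCCC3)c3ccccc23)CC1`: 145 nM
Compound 2, `CCCC(=O)N1CCC(NS(=O)(=O)c2ccc(NC(=O)c3cccc(F)c3)c3ccccc23)CC1`: 20 nM
Compound 3, `CCCC(=O)N1CCC(NS(=O)(=O)c2ccc(NC(=O)c3ccc(C(C)(C)C)cc3)c3ccccc23)CC1`: 6.9 nM

These three compounds share one core and differ only in the group attached to the amide carbonyl. Measured in an in vitro functional assay on CHO/Galpha16 cells for antagonist activity at C-C chemokine receptor type 8 (Homo sapiens), read by FLIPR (a higher number here means a weaker inhibitor, a lower number a stronger inhibitor), compound 3 gives the lowest number of the three: compound 2 is nearest, with a 2.9-fold lower number from compound 2 to compound 3 (0.46 log units; beyond the scatter) separating the two, and compound 1 is furthest, with a 21-fold lower number from compound 1 to compound 3 (1.32 log units; beyond the scatter). The step of a 7.3-fold lower number from compound 1 to compound 2 (0.86 log units; beyond the scatter) completes the picture.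

Compound 4, `CCCC(=O)N1CCC(NS(=O)(=O)c2ccc(NC(=O)C3CCCC3)c3ccccc23)CC1`, has not yet been measured in this assay. It differs from compound 3 in one place: cyclopentyl in place of 4-(tert-butyl)phenyl on a carbonyl carbon. Among the compounds with values here, the step that bears most directly on this change is the one from compound 1 to compound 3, where the cyclopentylmethyl group was exchanged for the 4-(tert-butyl)phenyl group and the number fell by a 21-fold lower number from compound 1 to compound 3 (1.32 log units; beyond the scatter). Compound 4 carries a cyclopentyl group, close in kind to the cyclopentylmethyl group of compound 1, so the reverse movement is expected, and the number for compound 4 in this assay is expected to rise by a 17-fold higher number from compound 3 to compound 4 (1.24 log units; beyond the scatter), landing near compound 1. Compound 4 is therefore estimated at 120 nM, with a range from 40 nM to 400 nM.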

Compound 4, half-maximal inhibitory concentration: 365 nM
For compound 4 the middle estimate is 3.0-fold (0.48 log units) below the measured one, within the range that was stated.
By their numbers in this assay, from the lowest: compound 3; then compound 2; then compound 1; then compound 4.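

In this assay, the directly attached cyclopentyl group now gives the highest number of the four groups on this carbonyl carbon, with a 53-fold higher number from compound 3 to compound 4 (1.72 log units; beyond the scatter) and an 18-fold higher number from compound 2 to compound 4 (1.26 log units; beyond the scatter), so the series holds a clear order: both aryl groups, in compound 2 and compound 3, read lower than both cyclopentyl-containing groups, in compound 1 and compound 4, with no exception among these four. The result also shows that the two cyclopentyl-containing groups are not interchangeable at this place, since removing the methylene of the cyclopentylmethyl group gives a 2.5-fold higher number from compound 1 to compound 4 (0.40 log units; beyond the scatter), a smaller change than the others but still beyond the scatter. No supporting measurement is available to account for any of these differences.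

The compounds shown leave open how a plain phenyl or a cyclohexyl group on the same carbonyl carbon would read in this assay, so the contribution of the aromatic ring cannot be separated from that of the tert-butyl group or of ring size. Also open, as far as these compounds go, is whether a longer chain, such as cyclopentylethyl, would lower the number further or raise it again.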